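The source may hold more compounds than are shown below. What is called first, only, known or untested is meant among the compounds shown, and "the series" means these compounds.

Measured so far:
Compound 1 `COc1ccc(OCCCCCCN2CCN(c3ccncc3)C2=O)cc1`: > 25000 nM
Compound 2 `O=C1N(CCCCCOc2ccc(-c3cccs3)cc2)CCN1c1ccncc1`: > 25000 nM

In a functional assay on cells (Homo sapiens) for cytotoxicity (on this read-out lower numbers stand for higher toxicity in this test and higher numbers for lower toxicity in this test), compound 1 gives > 25000 nM, which is a limit of the assay and not a number. Compound 2 likewise reaches only a limit, > 25000 nM. Both values sit at the limit of > 25000 nM in this assay, at which 2 of the 2 values shown sit, so compound 1 stands exactly where every value shown in this assay stands. Compound 3 `O=C1N(CCCCCCOc2ccc(-c3cccs3)cc2)CCN1c1ccncc1` differs from compound 1 by thiophen-2-yl in place of methoxy on an aromatic carbon. Within the data shown here, no measured step covers this change; no shift beyond the scatter is expected, and the expected step is a step that the limit leaves unreadable from compound 1 to compound 3. Compound 3 is expected at 30000 nM, within 12000 nM to 80000 nM.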

Compound 3, half-maximal cytotoxic concentration: > 25000 nM
Compound 3: only a limit was reported (the forecaster's own chance of this, stated with the estimate: 80%); the middle value does not contradict the limit.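

Compound 1 and compound 3 both stop at a limit of the assay in this assay, so no step can be read between them: the limit of > 25000 nM in this assay, at which 3 of the 3 values shown sit.

On these data alone, whether thiophen-2-yl in place of methoxy changes the read-out at all stays open, as does where any of the compounds truly lies beyond that limit.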